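Ester in place of acid on the carboxy end

The source may report more compounds than this note shows. Statements on the series, on what has been measured and on what is new or still open speak of the compounds shown alone.

Compound 1 `CC(=O)Nc1cccc(-c2ccc(C(=O)N(Cc3cccc(OCCCCCC(=O)O)c3)C(C)C)cc2)c1` in an ADME assay on Raji cells (Homo sapiens) for cytotoxicity, read by CellTiter-Glo and resazurin assay, with a stated time of 72 h (on this read-out lower numbers stand for an effect already at smaller amounts and higher numbers for an effect only at larger amounts of compound), reaches only the assay's limit, > 26000 nM.
Compound 2 `CCOc1cccc(-c2ccc(C(=O)N(Cc3cccc(OCCCCCC(=O)O)c3)C(C)C)cc2)c1` in this assay likewise gives a limit, > 20800 nM.
Compound 3 `COc1cc(OC)cc(-c2ccc(C(=O)N(Cc3cccc(OCCCCCC(=O)O)c3)C(C)C)cc2)c1` in this assay also gives a limit, > 26000 nM.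

All three measured compounds share one core and differ only in the group on the outer aromatic ring. Compound 1 stands at a limit rather than a number, and the two further values are limits as well (the limit of > 20800 nM in this assay, at which 1 of the 3 values shown sits, (the limit of > 26000 nM in this assay, at which 2 of the 3 values shown sit)). The steps a step that the two limits leave unreadable from compound 1 to compound 2, a step that the two limits leave unreadable from compound 1 to compound 3 and a step that the two limits leave unreadable from compound 2 to compound 3 therefore cannot be read in size or direction. For the measured compounds named here, compound 4 `CCOC(=O)CCCCCOc1cccc(CN(C(=O)c2ccc(-c3cccc(NC(C)=O)c3)cc2)C(C)C)c1` differs from compound 1 by ethyl in place of hydrogen on an oxygen next to a carbonyl group, a change at the carboxy end rather than on the aromatic ring, so none of the measured steps touches the same place. With every measured value at a limit and no readable step, no shift beyond the scatter is expected. The step that the limit leaves unreadable from compound 1 to compound 4 is thus an estimate only. Compound 4 is expected to give about 30000 nM, within a range from 10000 nM to 100000 nM, most likely reported again as a limit.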

Compound 4, half-maximal effective concentration: > 26000 nM
Compound 4: only a limit was reported (the forecaster's own chance of this, stated with the estimate: 80%); the middle value is on the limit's open side.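

In this assay compound 1 and compound 4 both give only limits, so the change from carboxy to ethoxycarbonyl cannot be read in size or direction. The compounds shown leave open at what concentration any of them would show an effect, and whether that change alters it at all.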